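The source may report more compounds than this note shows. Statements on the series, on what has been measured and on what is new or still open speak of the compounds shown alone.

Measured so far in a functional assay on the whole organism with Mus musculus as the target; on this read-out higher numbers stand for an effect only at larger amounts of compound and lower numbers for an effect already at smaller amounts
- compound 1 `CN1C(=O)CCC(Cc2ccc(Br)cc2)C1=O` gives 143 mg/kg
- compound 2 `O=C1CCC(Cc2ccc(C(F)(F)F)cc2)C(=O)N1` gives 119 mg/kg
- compound 3 `CN1C(=O)CCC(Cc2ccc(Cl)cc2)C1=O` gives 124 mg/kg

The value of compound 3 lies within the usual scatter of the values of both compound 1 and compound 2. Compound 4 `CN1C(=O)CCC(Cc2ccc(Cl)cc2Cl)C1=O` differs from compound 3 by one change chloro in place of hydrogen on an aromatic carbon in the form of chloro in place of hydrogen on an aromatic carbon, ortho to a large group and meta to a chloro group. Among the measured compounds shown here, the only measured step that bears on this is a 1.2-fold lower number from compound 1 to compound 3 (0.06 log units; within the scatter) for chloro in place of bromo, which is a swap of one group for another. For the measured compounds named here, no measured step adds a new group, so this guide is weak, and no change beyond the scatter is expected in this assay here. The expected size of the change is a 1.1-fold lower number from compound 3 to compound 4 (0.03 log units; within the scatter) on this estimate. For compound 4 the estimated value is 115 mg/kg with an expected range from 55 mg/kg to 230 mg/kg in repeated measurements.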

Compound 4, dose for half-maximal effect: 153 mg/kg
Beside the measured number, compound 4's estimate is 1.3-fold (0.12 log units) below it, and the stated range covers the measured number.
By their numbers in this assay, from the lowest: compounds 2, 3, 1 and 4 (each within the scatter of the next).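

Adding chloro on the aromatic carbon ortho to a large group and meta to a chloro group gives a 1.2-fold higher number from compound 3 to compound 4 (0.09 log units; within the scatter) in this assay. The earlier step only swapped one group for another, whereas this one adds a group where hydrogen stood, and at this position the added chloro causes no change that can be told from the scatter. No measurement at hand speaks to the reason for this result. From the compounds shown here alone, whether an amine or a methoxy group at this position would move the number beyond the scatter stays open. So does whether chloro here would behave the same without the other chloro group.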